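The compounds below may be only part of what the source reports. "The series", "measured", "known", "first", "only" and "open" are said of these compounds alone.

In an ADME assay on HEK293 cells (Homo sapiens) for cytotoxicity, with a stated time of 72 h (on this read-out higher numbers stand for an effect only at larger amounts of compound and lower numbers for an effect already at smaller amounts), compound 1 (`Cc1cc(NC(=O)Nc2ccc(C(C)(C)C)cc2)c2ccccc2n1`) gives > 25000 nM as a limit of the assay and not a number. Compound 2 (`Cc1cc(NC(=O)Nc2ccc(N(C)C)cc2)c2ccccc2n1`) gives > 25000 nM as a limit too, so its place is known only as a limit. Both compounds stand at the limit of > 25000 nM in this assay, at which 2 of the 2 values shown sit, and nothing firmer is available. Compound 3 (`Cc1cc(NC(=O)Nc2ccc(C(F)(F)F)cc2)c2ccccc2n1`) differs from compound 2 by one change (trifluoromethyl in place of dimethylamino on an aromatic carbon) with trifluoromethyl in place of dimethylamino on an aromatic carbon. Within the data shown here, the only measured step bearing on this is a step that the two limits leave unreadable from compound 1 to compound 2 and it gives no size to carry over. No change beyond the scatter is therefore expected in this assay, and the estimated step is a number no higher from compound 2 to compound 3 (the limit leaves the size open) without a firm direction. For compound 3 the estimated value is 25000 nM with an expected range of 12000 nM to 40000 nM and quite possibly only a limit will be reported.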

Compound 3, half-maximal effective concentration: 25000 nM
Beside the measured number, compound 3's estimate shows no gap at the digits printed, within the range that was stated.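

In this assay compound 3, with trifluoromethyl on the aromatic carbon para to a large group, is the only one of the three compounds shown to return a number, 25000 nM. Compound 2 gives > 25000 nM, which is a limit of the assay and not a number. Trifluoromethyl in place of dimethylamino gives a number no higher from compound 2 to compound 3 (the limit leaves the size open), and trifluoromethyl in place of tert-butyl gives a number no higher from compound 1 to compound 3 (the limit leaves the size open). Neither step can be read, so this change has no size at this position, because each of them rests on a limit: the limit of > 25000 nM in this assay, at which 2 of the 3 values shown sit.

The compounds shown leave open whether a carboxylic acid or a morpholine at this place would bring an effect at smaller amounts of compound in this assay. They also leave open how far the true values of compound 1 and compound 2 lie from that of compound 3.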